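A few compounds are considered here, and "the series" means these few. Any claim that something is new, unique, unknown or untested is made for them only; others in the source may bear on it.

Measured so far in an ADME assay for metabolic stability, at pH 1.5; a lower number here means that the compound disappears faster, a higher number that the compound lasts longer:

- compound 1 `COc1ccc2c(c1)COP(=O)(OCC1CCC(n3cnc4c(N)ncnc43)O1)O2`: 0.8 h
- compound 2 `COc1ccc2c(c1)COP(=O)(OC[C@@H]1C=C[C@H](n3cnc4c(N)ncnc43)O1)O2`: 0.011 h
- compound 3 `Nc1ncnc2c1ncn2C1CCC(COP2(=O)OCc3ccccc3O2)O1`: 0.6 h

Compound 1 and compound 3 share a core and differ in one place only, (hydrogen in place of methoxy on an aromatic carbon). The step that this change made is a 1.3-fold lower number from compound 1 to compound 3 (0.12 log units; within the scatter). Compound 2 carries a different core; how the two cores differ is not broken down here. In this assay compound 2 gives the lowest of the three half-lives, and the distance to both compound 1 and compound 3 lies beyond the scatter, so compound 2 is the shortest-lived of the measured set.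

Compound 4 `Nc1ncnc2c1ncn2[C@H]1C=C[C@@H](COP2(=O)OCc3ccccc3O2)O1` is not yet measured. It stands to compound 2 as compound 3 stands to compound 1: hydrogen in place of methoxy on an aromatic carbon. The two place descriptions read the same word for word, so this is the same change, made on the other core. Going by the values given here, the only guide to its size is the step from compound 1 to compound 3, which stayed within the scatter. For compound 4 the expectation is therefore a half-life close to that of compound 2, a step of about a 1.2-fold lower number from compound 2 to compound 4 (0.09 log units; within the scatter), resting on the near-flat step a 1.3-fold lower number from compound 1 to compound 3 (0.12 log units; within the scatter) seen on the first core. Compound 4 is estimated at 0.009 h, with a range from 0.004 h to 0.02 h expected to cover most repeats. Whether the second core responds to the loss of the methoxy as the first did is the point the measurement will settle.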

Compound 4, half-life: 0.01 h
Estimate against measurement, compound 4: 1.1-fold (0.05 log units) below; measured number inside the range.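

In this assay, going by these compounds alone, hydrogen in place of methoxy on an aromatic carbon of the second core gives a 1.1-fold lower number from compound 2 to compound 4 (0.04 log units; within the scatter), so on this core the change produces no step that can be told from repeat scatter. Set beside the earlier step, the result reads as the same flat outcome on both cores: the same change on two cores in this assay, a 1.3-fold lower number (0.12 log units; within the scatter) from compound 1 to compound 3 and a 1.1-fold lower number (0.04 log units; within the scatter) from compound 2 to compound 4, 1.2-fold (0.08 log units) apart, within the scatter of two such steps. Within the data shown here, this supports carrying the loss of the methoxy from one core to the other as a change of no readable size in this read-out, but it rests on only two cores and on a change that moves the half-life on neither, so it does not show that a step of real size would carry over in the same way, nor does it say anything about why the change is so quiet.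

The compounds shown hold only methoxy or hydrogen at this place, so a chlorine, a nitrile, an amine or a longer alkoxy chain on the same aromatic carbon remains open on either core. On these data alone, whether the flat step holds in any read-out other than this assay also remains open.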